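Semicarbazone aryl exchange: outlook for compound 3

The source may hold more compounds than are shown below. What is called first, only, known or untested is meant among the compounds shown, and "the series" means these compounds.

Measured so far in a functional assay on NCI-H460 cells (Homo sapiens) for cytotoxicity, read by MTT assay, with a stated time of 72 h; a lower number here means a stronger inhibitor, a higher number a weaker inhibitor:
compound 1 `COc1ccc(/C=N/NC(=O)Nc2ccc(Oc3ccnc(-c4nncn4CCN(C)C)c3)c(F)c2)c(OC)c1` gives 1570 nM
compound 2 `COc1cc(/C=N/NC(=O)Nc2ccc(Oc3ccnc(-c4nncn4CCN(C)C)c3)c(F)c2)cc(OC)c1OC` gives 2770 nM
compound 3 `COc1cc(/C=N/NC(=O)Nc2ccc(Oc3ccnc(-c4nncn4CCN(C)C)c3)c(F)c2)ccc1O` is not yet measured

Compound 2 stands within the scatter of compound 1 on the two numbers available, as a 1.8-fold higher number from compound 1 to compound 2 (0.25 log units; within the scatter) shows; the two cannot be ranked against each other.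

Compound 3 differs from compound 2 by 4-hydroxy-3-methoxyphenyl in place of 3,4,5-trimethoxyphenyl on a carbon with a double bond to nitrogen. Among the measured compounds shown here, no measured pair exchanges a methoxy for a hydroxyl on this ring, so the only step that bears on the change is the earlier aryl exchange a 1.8-fold higher number from compound 1 to compound 2 (0.25 log units; within the scatter), which remained within the scatter. On that basis a modest step, or none beyond the scatter, is expected in this assay, with no direction secured by the data. The estimate for compound 3 is 2200 nM, in the range 900 nM to 5500 nM. The expected step of a 1.3-fold lower number from compound 2 to compound 3 (0.10 log units; within the scatter) is accordingly small.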

Compound 3, half-maximal inhibitory concentration: 57 nM
Beside the measured number, compound 3's estimate is 39-fold (1.59 log units) above it; the measured number lies below the stated range.
By their numbers in this assay, from the lowest: compound 3; then compounds 1 and 2 (each within the scatter of the next).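

In this assay, the aryl group on a carbon with a double bond to nitrogen proves to be a sensitive place in this series, with a 49-fold lower number from compound 2 to compound 3 (1.69 log units; beyond the scatter) and a 28-fold lower number from compound 1 to compound 3 (1.44 log units; beyond the scatter), although the two methoxy-only aryl groups of compounds 1 and 2 could not be ranked against each other. Of the three aryl groups shown, only the 4-hydroxy-3-methoxyphenyl of compound 3 carries a hydroxyl, so among these compounds the low number goes with that group, and no compound goes against this. No measurement on hand accounts for the size of these steps.

The compounds shown do not separate the gain from the hydroxyl from that of the methoxy groups present or absent on the ring. Also open, going by these compounds, is whether an amine or a carboxylic acid in the place of that hydroxyl would keep the number near that of compound 3.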